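This account rests on a few compounds, and the source may have more. Where it says the series, first, only, none or still open, it means among the compounds named here.

Compound 1 `CC(=O)N[C@@H]1CCC[C@H](C(=O)Nc2cc(-c3cnn4c3CCCC4)c(Cl)cn2)C1` gives 3.2 in a physicochemical assay for lipophilicity, using the shake flask method, measured as octanol-water partition, at pH 7.4; a lower number here means a more polar compound, a higher number a more lipophilic compound.
Compound 2 `CC(=O)N[C@@H]1CCC[C@H](C(=O)Nc2cc(-c3cnn(C)c3C)c(Cl)cn2)C1` gives 2.6 in this assay.

Compound 2 stands lowest of the two numbers in this assay; its nearest neighbour is compound 1, which lies higher by a step beyond the scatter, a number 0.60 log units lower from compound 1 to compound 2 (beyond the scatter). Compound 3 `CC(=O)N[C@@H]1CCC[C@H](C(=O)Nc2cc(-c3cnn4c3CCCCC4)c(Cl)cn2)C1` differs from compound 2 in one place: a group of 10 heavy atoms (8 carbon, 2 nitrogen; one five-membered aromatic ring with 2 hetero atoms, one seven-membered non-aromatic ring with 1 hetero atom) in place of a group of 7 heavy atoms (5 carbon, 2 nitrogen; one five-membered aromatic ring with 2 hetero atoms), on an aromatic carbon. Going by the values given here, the one measured step that bears on this change runs the other way, from the fused six-membered ring of compound 1 to the two methyl groups of compound 2, and it was modest and beyond the scatter, a number 0.60 log units lower from compound 1 to compound 2 (beyond the scatter). Compound 3 carries a fused seven-membered ring, one carbon more than compound 1, so the step in this assay is expected to be upward and somewhat larger than that earlier one, a number 0.90 log units higher from compound 2 to compound 3 (beyond the scatter). For compound 3 the estimate in this assay is therefore 3.5, in the range 3.1 to 3.9.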

Compound 3, distribution coefficient: 3.6
Estimate against measurement, compound 3: 0.10 log units below; low and high end bracket the measured number.
By their numbers in this assay, from the lowest: compound 2; then compound 1; then compound 3.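

In this assay, going by these compounds alone, the seven-membered ring of compound 3 gives a number 1.00 log units higher from compound 2 to compound 3 (beyond the scatter), and the position also separates the two fused rings, with a number 0.40 log units higher from compound 1 to compound 3 (beyond the scatter), a difference that the earlier compounds could not show. Across these three compounds, the groups on this aromatic carbon now give a clear order, with every step beyond the scatter: the 1,5-dimethyl-1H-pyrazol-4-yl group of compound 2 lowest, the six-membered fused ring of compound 1 next and the seven-membered fused ring of compound 3 highest. Nothing given here accounts for these steps.

Three compounds cannot show whether the rise with ring size continues to an eight-membered fused ring or extends down to a five-membered one. They also leave open how an amine or a hydroxyl group on the fused ring would shift the number in this assay.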